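Moving the Bromine on the Benzyl Group

The compounds below may be only part of what the source reports. "The series", "measured", "known", "first", "only" and "open" are said of these compounds alone.

Within the data shown here, compound 2 `O=C(NC1CCN(Cc2cccc(Br)c2)CC1)c1cccc2ccccc12` gives 66 nM in an assay on isolated protein for displacement of a labelled ligand from D(4) dopamine receptor (Homo sapiens) (on this read-out lower numbers stand for stronger inhibition and higher numbers for weaker inhibition), the lower of the two numbers known so far, while compound 1 `O=C(NC1CCN(Cc2ccccc2Cl)CC1)c1cccc2ccccc12` gives 329 nM. Among the measured compounds shown here, the one measured step, a 5.0-fold lower number from compound 1 to compound 2 (0.70 log units; beyond the scatter), changed both the halogen and where it sits at once, so it bears only loosely on compound 3 `O=C(NC1CCN(Cc2ccc(Br)cc2)CC1)c1cccc2ccccc12`, where (4-bromophenyl in place of 3-bromophenyl on a saturated chain carbon bound to an amine nitrogen in a ring). For the measured compounds named here, with the bromine kept and only its place on the ring shifted, no step here speaks to a change of that kind, so a step within the scatter is expected for a 1.2-fold higher number from compound 2 to compound 3 (0.08 log units; within the scatter). Compound 3 is therefore estimated at 80 nM, within 25 nM to 250 nM.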

Compound 3, inhibition constant: 44 nM
The estimate for compound 3 lay 1.8-fold (0.26 log units) above the measured number, within the range that was stated.
By their numbers in this assay, from the lowest: compounds 3 and 2 (each within the scatter of the next); then compound 1.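

Shifting the bromine gave a 1.5-fold lower number from compound 2 to compound 3 (0.18 log units; within the scatter) in this assay, so on this benzyl ring the 3-bromophenyl and 4-bromophenyl groups cannot be told apart. The step from the 2-chlorophenyl group, a 7.5-fold lower number from compound 1 to compound 3 (0.87 log units; beyond the scatter), is of similar size to the earlier step and again changes the halogen and its place together. No supporting evidence bears on these numbers.

From the compounds shown here alone, how much of the gap to compound 1 belongs to the halogen and how much to its place stays open. Also open, going by these compounds, is how a group such as an amine or a carboxylic acid would read in place of the bromine.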